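The source may hold more compounds than are shown below. What is called first, only, known or untested is meant among the compounds shown, and "the series" means these compounds.

Measured so far in an assay on cell membranes from kidney for displacement of a labelled ligand from Translocator protein (Rattus norvegicus); on this read-out lower numbers stand for stronger inhibition and higher numbers for weaker inhibition:
compound 1 `CCN(Cc1ccccc1)C(=O)c1nc(-c2ccccc2)c2cc(Cl)ccc2n1` gives 24.3 nM;
compound 2 `CCN(Cc1ccccc1)C(=O)c1nc(-c2ccccc2Cl)c2ccccc2n1` gives 0.235 nM;
compound 3 `CCN(Cc1ccccc1)C(=O)c1nc(-c2ccc(F)cc2)c2ccccc2n1` gives 1.68 nM.

Compound 3 holds the second highest of the three numbers. Compound 2 sits lower, separated from it by a 7.1-fold higher number from compound 2 to compound 3 (0.85 log units; beyond the scatter); compound 1 sits higher, and the two values alone show that gap.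

Compound 4 `CCN(Cc1ccccc1)C(=O)c1nc(-c2ccc(Cl)cc2)c2ccccc2n1` differs from compound 3 by chloro in place of fluoro on an aromatic carbon. For the measured compounds named here, the one measured step, a 7.1-fold higher number from compound 2 to compound 3 (0.85 log units; beyond the scatter), exchanges the halogen and its place at once, so it does not isolate a chloro against a fluoro at the same place. Compound 4 is therefore expected to stay near compound 3, with an estimated step of a 1.1-fold lower number from compound 3 to compound 4 (0.05 log units; within the scatter) that lies within the scatter. Compound 4 is estimated at 1.5 nM, in the range 0.4 nM to 6 nM.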

Compound 4, inhibition constant: 0.762 nM
For compound 4 the middle estimate is 2.0-fold (0.29 log units) above the measured one, within the range that was stated.
By their numbers in this assay, from the lowest: compound 2; then compound 4; then compound 3; then compound 1.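

In this assay the exchange of 4-fluorophenyl for 4-chlorophenyl changes the halogen alone and gives (a 2.2-fold lower number from compound 3 to compound 4 (0.34 log units; beyond the scatter)), a modest step beyond the scatter. With chloro kept and its place changed, 4-chlorophenyl in place of 2-chlorophenyl gives (a 3.2-fold higher number from compound 2 to compound 4 (0.51 log units; beyond the scatter)), so the halogen and its place each shift the number on their own. Nothing measured here explains either step.

The compounds shown leave open how a methoxy group or an amine would compare with chloro at this place. They also leave open whether 2-fluorophenyl would follow 2-chlorophenyl.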